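Swapping the halogenated aryl group on compound 2

This account rests on a few compounds, and the source may have more. Where it says the series, first, only, none or still open, it means among the compounds named here.

Compound 2 `C=CCn1c(=O)/c(=C\c2ccc(F)c(Br)c2)[nH]c(=O)/c1=C\c1ccccc1OC` was tested in a functional assay on NCI-H1975 cells (Homo sapiens) for cytotoxicity, read by CCK-8 assay, with a stated time of 72 h (a lower number here means a stronger inhibitor, a higher number a weaker inhibitor), and came out as "not active" (no number reported), so no number is available for it. Compound 4 `C=CCn1c(=O)/c(=C\c2ccccc2Cl)[nH]c(=O)/c1=C\c1ccccc1OC` differs from compound 2 in one place: 2-chlorophenyl in place of 3-bromo-4-fluorophenyl on a double-bonded chain carbon bound to an aromatic carbon. Among the measured compounds, compound 1 `COc1ccccc1/C=c1\c(=O)[nH]/c(=C/c2cccc(Cl)c2Cl)c(=O)n1C` gives 300 nM and compound 3 `COc1ccccc1/C=c1/[nH]c(=O)/c(=C\c2ccccc2OC)n(C)c1=O` gives 16900 nM, and the step between them, a 56-fold higher number from compound 1 to compound 3 (1.75 log units; beyond the scatter), shows that the group at this position can shift the result strongly. Within the data shown here, no measured step covers the exact change from compound 2 to compound 4, and compound 2 itself has no number, so the direction can only be guessed from compound 1, whose chlorinated aryl group is nearer to that of compound 4. Compound 4 is therefore expected to give roughly 4000 nM, with a plausible range of 600 nM to 30000 nM.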

Compound 4, half-maximal inhibitory concentration: 9200 nM
For compound 4 the middle estimate is 2.3-fold (0.36 log units) below the measured one; measured number inside the range.
By their numbers in this assay, from the lowest: compound 1; then compounds 4 and 3 (each within the scatter of the next).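

Among these compounds, compound 2 has no number in this assay and so gives no step to compound 4. The compounds shown leave open how 2-chlorophenyl and 3-bromo-4-fluorophenyl compare at this place. No supporting evidence bears on this result.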